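The source may hold more compounds than are shown below. What is called first, only, known or untested is meant among the compounds shown, and "the series" means these compounds.

Working notes on the amide series. All three measured compounds share one core and differ only in the group on the amide nitrogen. Compound 1 `CCn1c(C(=O)NCCNC(=O)OC(C)(C)C)ccc1C(CC)(CC)c1ccc(OCS(=O)(=O)c2ccccc2)c(C)c1` carries a 2-((tert-butoxycarbonyl)amino)ethyl group there. In a functional assay on PC-3 cells (Homo sapiens) for antiproliferative activity, read by MTT assay, with a stated time of 24 h (a higher number here means a weaker inhibitor, a lower number a stronger inhibitor), compound 1 reaches only the assay limit, > 50000 nM; that value is a limit, not a number (the limit of > 50000 nM in this assay, at which 1 of the 3 values shown sits). Compound 2 `CCn1c(C(=O)N[C@@H](CO)C(C)C)ccc1C(CC)(CC)c1ccc(OCS(=O)(=O)c2ccccc2)c(C)c1` gives 10600 nM in this assay. Compound 3 `CCn1c(C(=O)N[C@H](CO)CCO)ccc1C(CC)(CC)c1ccc(OCS(=O)(=O)c2ccccc2)c(C)c1` gives 12100 nM in this assay, the highest of the two numbers shown, with compound 2 nearest; the step of a 1.1-fold higher number from compound 2 to compound 3 (0.06 log units; within the scatter) lies within the scatter. Against compound 1 both hydroxyl-bearing amides move the number down: an at least 4.7-fold lower number from compound 1 to compound 2 (0.67 log units; beyond the scatter) and an at least 4.1-fold lower number from compound 1 to compound 3 (0.61 log units; beyond the scatter).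

Compound 4 `CCn1c(C(=O)N[C@H](CCC(=O)O)C(=O)O)ccc1C(CC)(CC)c1ccc(OCS(=O)(=O)c2ccccc2)c(C)c1` has not been measured in this assay. It differs from compound 3 in one place: 1,3-dicarboxypropyl in place of 3-hydroxy-1-(hydroxymethyl)propyl on an amide-type nitrogen. Within the data shown here, no measured step swaps hydroxyl groups for carboxylic acids; the only step at this position between two numbered compounds, a 1.1-fold higher number from compound 2 to compound 3 (0.06 log units; within the scatter), is within the scatter, while the steps from compound 1 show that a bulky carbamate-capped chain gives a limit. A small rise is therefore expected, a 1.7-fold higher number from compound 3 to compound 4 (0.22 log units; within the scatter), with a real chance that compound 4 again returns only a limit. The estimate for compound 4 in this assay is 20000 nM, within 8000 nM to 60000 nM.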

Compound 4, half-maximal inhibitory concentration: > 50000 nM
Compound 4 gave a limit, no number; the forecaster's own chance of this, stated with the estimate: 35%; at least 2.5-fold (0.39 log units) between middle value and limit.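

The 1,3-dicarboxypropyl group has the same counted hydrogen-bond donors and acceptors as the group it replaces, yet in this assay it gives an at least 4.1-fold higher number from compound 3 to compound 4 (0.61 log units; beyond the scatter), and against the other hydroxyl-bearing amide it gives an at least 4.7-fold higher number from compound 2 to compound 4 (0.67 log units; beyond the scatter). Among these compounds, the earlier compounds showed one exchange between hydroxyl-bearing groups that stayed within the scatter, so this is the first evidence that a change confined to these hydroxyl-bearing and acid-bearing chains on the amide-type nitrogen can move the read-out beyond it. Compound 4 yields a limit, not a number, and so does compound 1, so the step between them cannot be read, and two unrelated groups now end at the same limit: the limit of > 50000 nM in this assay, at which 2 of the 4 values shown sit.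

The compounds shown do not separate the two carboxylic acids from the larger group that carries them, so a single carboxylic acid paired with a hydroxymethyl group, or the corresponding methyl esters, would be the direct test. As far as these compounds go, whether an amine or a longer hydroxyalkyl chain at this position would hold a number in this assay also stays open.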